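Swapping 4-hydroxycyclohexyl for benzyl in a cell assay

A few compounds are considered here, and "the series" means these few. Any claim that something is new, unique, unknown or untested is made for them only; others in the source may bear on it.

Compound 1 (`O=C(NCCNS(=O)(=O)c1ccc(-c2ccccc2O[C@H]2CC[C@@H](O)CC2)s1)Nc1ccc([N+](=O)[O-])cc1`) gives 12400 nM in a functional assay on RS4-11 cells (Homo sapiens) for inhibition, read by CCK-8 assay, with a stated time of 48 h; on this read-out higher numbers stand for weaker inhibition and lower numbers for stronger inhibition
Compound 2 (`O=[N+]([O-])c1ccc(NC(=S)NCCNS(=O)(=O)c2ccc(-c3ccccc3O[C@H]3CC[C@@H](O)CC3)s2)cc1`) gives 9400 nM in this assay

On these numbers, compound 2 cannot be told apart from compound 1. Within the data shown here, the one measured step is a 1.3-fold lower number from compound 1 to compound 2 (0.12 log units; within the scatter) and it lies at another place in the molecule, so it offers no direct guide to the next change.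

Compound 3 (`O=[N+]([O-])c1ccc(NC(=S)NCCNS(=O)(=O)c2ccc(-c3ccccc3OCc3ccccc3)s2)cc1`) differs from compound 2 by benzyl in place of 4-hydroxycyclohexyl on an oxygen on an aromatic ring and carries benzyl in place of 4-hydroxycyclohexyl on an oxygen on an aromatic ring. Among the measured compounds shown here, no measured pair tests this swap, so the data favour no direction. Compound 2 at 9400 nM is therefore the natural starting point, and the range must stay wide.

The expected change is a 1.3-fold lower number from compound 2 to compound 3 (0.13 log units; within the scatter) and no shift beyond the scatter is anticipated. The estimated value for compound 3 is 7000 nM with an expected range from 2000 nM to 25000 nM in this measurement.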

Compound 3, half-maximal inhibitory concentration: 11300 nM
The estimate for compound 3 lay 1.6-fold (0.21 log units) below the measured number; low and high end bracket the measured number.
By their numbers in this assay, from the lowest: compounds 2, 3 and 1 (each within the scatter of the next).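

On an oxygen on an aromatic ring, benzyl in place of 4-hydroxycyclohexyl gives a 1.2-fold higher number from compound 2 to compound 3 (0.08 log units; within the scatter) in this assay. Among these compounds, this is the first reading at this position, and it shows that a non-aromatic ring with a hydrogen-bond donor, a hydrogen-bond acceptor and defined stereocentres cannot be told apart here from an aromatic ring with none of these. No available evidence bears on why the two groups read alike.

Still open, going by these compounds, is whether an amine, a carboxylic acid or a longer chain on this oxygen would move the number beyond the scatter. Also open, on these data alone, is whether the same swap would read alike on compound 1.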